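Swapping the aryl group on the propanamide chain

The source may report more compounds than this note shows. Statements on the series, on what has been measured and on what is new or still open speak of the compounds shown alone.

For the measured compounds named here, compound 1 `COc1cccc(CCC(=O)Nc2nc3ccccc3c(=O)s2)c1` is one of three compounds measured in an assay on CHO cells for displacement of a labelled ligand from adenosine receptor A2b (Homo sapiens), read by scintillation counting, with a stated time of 75 min (a higher number here means a weaker inhibitor, a lower number a stronger inhibitor), where compound 1 gives 225 nM. This is the lower of the two values that came out as numbers, though the gap to compound 3 `O=C(CCCc1ccccc1)Nc1nc2sccc2c(=O)s1`, which gives 361 nM, lies within the scatter of the method. Compound 2 `COc1cccc(C#CC(=O)Nc2nc3ccccc3c(=O)s2)c1` gives only > 1000 nM, which is a limit of this assay and not a number (the limit of > 1000 nM in this assay, at which 1 of the 3 values shown sits).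

Compound 4 `O=C(CCc1ccccc1F)Nc1nc2ccccc2c(=O)s1` has not yet been measured. It differs from compound 1 in one place: 2-fluorophenyl in place of 3-methoxyphenyl on a saturated chain carbon, two bonds along the chain from a carbonyl carbon. Going by the values given here, no step between measured compounds matches this change, so its size can only be judged from the spread of the numbers already in hand. The chain and the amide link are unchanged, and the aryl group keeps its size; the methoxy group is lost and a fluorine arrives. A step from compound 1 to compound 4 of about a 1.3-fold higher number from compound 1 to compound 4 (0.12 log units; within the scatter) is expected, that is, nothing clearly beyond the scatter. Compound 4 is therefore estimated at 300 nM, within 120 nM to 800 nM.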

Compound 4, inhibition constant: 801 nM
Beside the measured number, compound 4's estimate is 2.7-fold (0.43 log units) below it; measured number above the stated range.
By their numbers in this assay, from the lowest: compounds 1 and 3 (each within the scatter of the next); then compound 4. At a limit, above all of these: compound 2.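

In this assay, 2-fluorophenyl in place of 3-methoxyphenyl on a saturated chain carbon, two bonds along the chain from a carbonyl carbon, gives a 3.6-fold higher number from compound 1 to compound 4 (0.55 log units; beyond the scatter). This is the first single change shown, and it establishes that exchanging the aryl group alone, with the chain and amide link unchanged, can move the number beyond the scatter. Nothing measured here accounts for the step or separates the loss of the methoxy group from the arrival of the fluorine.

From the compounds shown here alone, whether a plain phenyl, a 3-fluorophenyl or a 2-methoxyphenyl group on this chain would fall nearer compound 1 or compound 4 remains open. Also open, going by these compounds, is how a pyridyl ring or a longer chain carrying the 3-methoxyphenyl group would read in this assay.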